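This account rests on a few compounds, and the source may have more. Where it says the series, first, only, none or still open, it means among the compounds named here.

Compound 1 `CCCCC[C@H](CN(O)C=O)C(=O)NCNC(=O)c1cc2cccc(OC)c2o1` gives 160 nM in an assay on CHO cells for inhibition of bone morphogenetic protein 1 (Homo sapiens), with stated times of 10 min and 60 min; on this read-out higher numbers stand for weaker inhibition and lower numbers for stronger inhibition. Its two neighbours sit within the usual scatter of it: compound 2 `CCCCC[C@@H](C(=O)NCNC(=O)c1cc2cccc(OC)c2o1)[C@@H](CC)N(O)C=O` gives 126 nM, a step of a 1.3-fold lower number from compound 1 to compound 2 (0.10 log units; within the scatter), and compound 3 `COc1cccc2cc(C(=O)NCNC(=O)[C@H](Cc3ccccc3)CN(O)C=O)oc12` gives 160 nM, a step of no change at the digits printed from compound 1 to compound 3 (within the scatter). Compound 4 `CCCCC[C@@H](CN(O)C=O)C(=O)NCNC(=O)c1cc2cccc(OC)c2o1` is the next candidate, differing from compound 1 in this way: the two compounds have the same atoms and bonds and differ only in configuration as drawn: 1 of 1 stereo elements differ; a stereocentre at a saturated chain carbon is drawn R in compound 1 and S in compound 4. Among the measured compounds shown here, neither of the two measured steps touches configuration, so no measured step bears on this one, and how this assay reads the other hand at that carbon is unknown. An enantiomer is commonly read differently from its partner, so compound 4 is expected to give a weaker number, though with wide uncertainty. The estimate for compound 4 is therefore 600 nM, likely between 150 nM and 3000 nM, a step of a 3.8-fold higher number from compound 1 to compound 4 (0.57 log units; beyond the scatter).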

Compound 4, half-maximal inhibitory concentration: 4000 nM
Compound 4: middle estimate off by 6.7-fold (0.82 log units), on the low side, outside the stated range (above it).
By their numbers in this assay, from the lowest: compounds 2, 1 and 3 (each within the scatter of the next); then compound 4.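

In this assay, the hand at this saturated chain carbon matters far more than either substituent change seen so far: a 25-fold higher number from compound 1 to compound 4 (1.40 log units; beyond the scatter). Among the compounds shown here, the ethyl and phenyl steps, a 1.3-fold lower number from compound 1 to compound 2 (0.10 log units; within the scatter) and no change at the digits printed from compound 1 to compound 3 (within the scatter), both stayed within the scatter, so this is the first change in the set to separate two compounds clearly. The R drawing at this carbon is the one that reads stronger, and the gap can be tied to that centre alone: the fact that compounds 1 and 4 differ only in the configuration as drawn

On these data alone, whether the other hand costs as much in the phenyl compound 3 remains open. So does how a longer chain in place of the butyl of compound 1 would read.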